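Adding Trifluoromethyl to a Benzylamino Acid Agonist

The compounds below may be only part of what the source reports. "The series", "measured", "known", "first", "only" and "open" are said of these compounds alone.

Of the compounds shown here, two that share a common core have been measured in a functional assay on 1321-N1 cells for agonist activity at Free fatty acid receptor 1 (Homo sapiens), read by calcium flux; a higher number here means that more compound is needed for the effect, a lower number that less compound is needed. Compound 1 `O=C(O)CCc1ccc(NCc2ccccc2)cc1` gives 759 nM in this assay, the lowest of the two numbers. Compound 2 `O=C(O)CCc1ccc(COc2ccccc2)cc1` gives 6310 nM in this assay, a number that lies above that of compound 1 by more than the usual scatter. The not yet measured compound 3 `O=C(O)CCc1ccc(NCc2cccc(C(F)(F)F)c2)cc1` differs from compound 1 only by trifluoromethyl in place of hydrogen on an aromatic carbon. Among the compounds with values here, no pair of measured compounds shows what such a substitution does here, so the size of the step cannot be read from the data; a modest move toward less compound being needed is expected, with an estimated step of a 2.5-fold lower number from compound 1 to compound 3 (0.40 log units; beyond the scatter). Compound 3 is therefore expected to give about 300 nM in this assay, with a plausible range from 100 nM to 1200 nM.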

Compound 3, half-maximal effective concentration: 186 nM
Compound 3: middle estimate off by 1.6-fold (0.21 log units), on the high side; the measured number falls inside the stated range.
By their numbers in this assay, from the lowest: compound 3; then compound 1; then compound 2.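

Trifluoromethyl in place of hydrogen, on an aromatic carbon meta to a large group, gives a 4.1-fold lower number from compound 1 to compound 3 (0.61 log units; beyond the scatter) in this assay. Within the data shown here, this is the first measured step at this position, and it shows that a group of 4 heavy atoms can replace a lone hydrogen here with less compound needed for the effect, not more. Nothing in the data bears on the reason for this drop.

A single substitution cannot tell whether the drop is particular to trifluoromethyl or whether a chlorine atom, a methyl group or a methoxy group at the same carbon would give a similar step. From the compounds shown here alone, it is also open whether trifluoromethyl on another carbon of that ring, or on the core of compound 2, would lower the number to the same extent.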